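Swapping Trifluoromethyl for Hydroxymethyl on a Shared Core

The source may hold more compounds than are shown below. What is called first, only, known or untested is meant among the compounds shown, and "the series" means these compounds.

Compound 1, `O=c1[nH]c(=O)n(COCCO)cc1[N+](=O)[O-]`: > 432000 nM, a limit of the test.
Compound 2, `Nc1cn(COCCO)c(=O)[nH]c1=O`: > 497000 nM, a limit of the test.
Compound 3, `O=c1[nH]c(=O)n(COCCO)cc1C(F)(F)F`: > 393000 nM, a limit of the test.

These three compounds share one core and differ only in the group on a single aromatic carbon. In a functional assay on HepG2 cells (Homo sapiens) for cytotoxicity, read by MTT assay (on this read-out lower numbers stand for higher toxicity in this test and higher numbers for lower toxicity in this test), none of them gave a number. For compound 1 the result is only a limit, (the limit of > 432000 nM in this assay, at which 1 of the 3 values shown sits). For compound 2 the result is likewise only a limit, (the limit of > 497000 nM in this assay, at which 1 of the 3 values shown sits). Compound 3 stands at its own limit, (the limit of > 393000 nM in this assay, at which 1 of the 3 values shown sits), so its entry is the edge of the test and not a number. The three steps among the measured compounds are therefore unreadable: a step that the two limits leave unreadable from compound 1 to compound 2, a step that the two limits leave unreadable from compound 1 to compound 3 and a step that the two limits leave unreadable from compound 2 to compound 3.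

Compound 4, `O=c1[nH]c(=O)n(COCCO)cc1CO`, has not been measured. It arises from compound 3 by hydroxymethyl in place of trifluoromethyl on an aromatic carbon. Within the data shown here, no measured step gives a readable size, so no direction can be drawn from them; the three limits show only that exchanges at this aromatic carbon have kept every compound at the edge of the test. In this assay the step is expected to be a step that the limit leaves unreadable from compound 3 to compound 4. Compound 4 is estimated at 500000 nM, within a range from 150000 nM to 2000000 nM, and most likely the test will again report only a limit.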

Compound 4, half-maximal cytotoxic concentration: > 476000 nM
Compound 4: a limit, no number (the forecaster's own chance of this, stated with the estimate: 85%); the middle value lies beyond the limit too.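

Compound 4 ends at a limit of the test, as do compound 1, compound 2 and compound 3, and none of its steps to those three compounds can be read. The compounds shown leave open whether the group on this aromatic carbon makes any difference in this assay.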